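Swapping dimethylamino for methoxymethoxy on a shared core

The compounds below may be only part of what the source reports. "The series", "measured", "known", "first", "only" and "open" are said of these compounds alone.

Compound 1 `CC(=O)O[C@]1(C)/C=C/C(=O)/C(CO)=C\C[C@](C)(CCC=C(C)C)/C=C/[C@H]1OC(=O)C=C(C)C` gives 3080 nM
Compound 2 `CO[C@]1(C)/C=C/C(=O)/C(CO)=C\C[C@](C)(CCC=C(C)C)/C=C/[C@H]1OC(=O)C=C(C)C` gives 15800 nM
Compound 3 `CC(C)=CCC[C@]1(C)/C=C/[C@@H](OC(=O)C=C(C)C)[C@](C)(O)/C=C/C(=O)/C(CN(C)C)=C\C1` gives 820 nM

In a functional assay on SMMC-7721 cells (Homo sapiens) for antiproliferative activity, read by MTT assay, with a stated time of 48 h (a higher number here means a weaker inhibitor, a lower number a stronger inhibitor), compound 3 has the lowest of the three numbers (820 nM), beyond the scatter of both others. Compound 4 `COCOC/C1=C/C[C@](C)(CCC=C(C)C)/C=C/[C@@H](OC(=O)C=C(C)C)[C@](C)(O)/C=C/C1=O` differs from it by methoxymethoxy in place of dimethylamino on a saturated chain carbon bound to a double-bonded ring carbon with methoxymethoxy in place of dimethylamino on a saturated chain carbon bound to a double-bonded ring carbon. Among the measured compounds shown here, no measured step covers this swap. For the measured compounds named here, the only step, a 5.1-fold higher number from compound 1 to compound 2 (0.71 log units; beyond the scatter), is modest and concerns a different change, so it gives only a rough idea of size. Compound 1 (3080 nM) and compound 2 (15800 nM) lack dimethylamino and both read higher, though they also differ from compound 3 elsewhere. The expected change is a 3.7-fold higher number from compound 3 to compound 4 (0.56 log units; beyond the scatter) in this assay toward a weaker inhibitor. For compound 4 the estimate is 3000 nM within an expected range of 1000 nM to 9000 nM when measured.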

Compound 4, half-maximal inhibitory concentration: 3250 nM
Compound 4: the middle estimate sits 1.1-fold (0.03 log units) below what was measured; the range from low to high includes it.
By their numbers in this assay, from the lowest: compound 3; then compounds 1 and 4 (each within the scatter of the next); then compound 2.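

In this assay, among the compounds shown here, the step of a 4.0-fold higher number from compound 3 to compound 4 (0.60 log units; beyond the scatter) is the first direct reading of a change on a saturated chain carbon bound to a double-bonded ring carbon, with methoxymethoxy in place of dimethylamino. It shows that this position responds to the group it carries, and that dimethylamino gives the lower number of this pair. No supporting evidence offers a reason for the difference. For the compounds shown here, with only two groups compared here on an otherwise identical core, it remains open whether another amine, such as pyrrolidine, would keep the lower number, or how a carboxylic acid would read.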